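From a Hexyl Chain to a Cyclohexyl Ring

The source may report more compounds than this note shows. Statements on the series, on what has been measured and on what is new or still open speak of the compounds shown alone.

Compound 1 `CCCCCCC(=O)Nc1ccn([C@@H]2CO[C@H](CO)O2)c(=O)n1`: 2400 nM
Compound 2 `CCCCCCCCCC(=O)Nc1ccn([C@@H]2CO[C@H](CO)O2)c(=O)n1`: 40 nM

Within the data shown here, in a functional assay on SW1573 cells (Homo sapiens) for cytotoxicity, read by sulforhodamine B assay, with a stated time of 72 h (a lower number here means a stronger inhibitor, a higher number a weaker inhibitor), compound 1 gives 2400 nM, the higher of the two numbers measured so far. Compound 3 `O=C(Nc1ccn([C@@H]2CO[C@H](CO)O2)c(=O)n1)C1CCCCC1` keeps the core of compound 1 and changes one group: cyclohexyl in place of hexyl on a carbonyl carbon. Among the measured compounds shown here, only one measured step bears on this change. It is a 60-fold lower number from compound 1 to compound 2 (1.78 log units; beyond the scatter), a large step that came with propyl in place of hydrogen on a saturated chain carbon, six bonds along the chain from a carbonyl carbon. For the measured compounds named here, compound 3 has no such chain extension, and no measured compound has a ring at this place, so that step is only an indirect guide. The expected step in this assay is a 2.1-fold higher number from compound 1 to compound 3 (0.32 log units; beyond the scatter), a modest move toward a higher number. Compound 3 is estimated at 5000 nM, with an expected range of 1500 nM to 20000 nM.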

Compound 3, half-maximal inhibitory concentration: 14000 nM
Estimate against measurement, compound 3: 2.8-fold (0.45 log units) below; measured number inside the range.
By their numbers in this assay, from the lowest: compound 2; then compound 1; then compound 3.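

In this assay, putting cyclohexyl in place of hexyl on a carbonyl carbon gives a 5.8-fold higher number from compound 1 to compound 3 (0.77 log units; beyond the scatter). Among these compounds, the earlier step showed only that the number falls as the open chain grows. This one shows that carbon count alone does not set the number at this position, since hexyl and cyclohexyl carry the same count of carbon atoms yet their values differ beyond the scatter. Nothing measured here explains why the ring gives the higher number.

On these data alone, it remains open whether this rise belongs to cyclohexyl alone or to rings at this position in general. A phenyl ring, or a cyclohexyl ring carried on a longer chain, might follow either cyclohexyl or the open chains, and the compounds shown do not settle which.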